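Aryl swap on the amine nitrogen: fluorine for chlorine

The source may hold more compounds than are shown below. What is called first, only, known or untested is meant among the compounds shown, and "the series" means these compounds.

Compound 1 `CCCCCCCCNc1nc(SCc2ccc(C(F)(F)F)cc2)nc2ccccc12` gives 22300 nM in a functional assay on MDA-MB-231 cells (Homo sapiens) for cytotoxicity, read by MTT assay, with a stated time of 72 h; a higher number here means a weaker inhibitor, a lower number a stronger inhibitor; compound 2 `FC(F)(F)c1ccc(CSc2nc(Nc3cccc(Cl)c3)c3ccccc3n2)cc1` gives 18000 nM in this assay. The step of a 1.2-fold lower number from compound 1 to compound 2 (0.09 log units; within the scatter) leaves compound 2 sitting alongside compound 1, the two numbers within the scatter of each other. Compound 3 `Fc1ccc(Nc2nc(SCc3ccc(C(F)(F)F)cc3)nc3ccccc23)cc1` differs from compound 2 by 4-fluorophenyl in place of 3-chlorophenyl on a nitrogen on an aromatic ring. Among the compounds with values here, no measured step exchanges one aryl group for another on this nitrogen; the single step available, a 1.2-fold lower number from compound 1 to compound 2 (0.09 log units; within the scatter), was itself within the scatter, so no shift beyond the scatter is expected, namely no change at the digits printed from compound 2 to compound 3 (within the scatter). For compound 3 the estimate in this assay is 18000 nM, with a range from 7000 nM to 45000 nM.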

Compound 3, half-maximal inhibitory concentration: 15000 nM
Beside the measured number, compound 3's estimate is 1.2-fold (0.08 log units) above it, and the stated range covers the measured number.
By their numbers in this assay, from the lowest: compounds 3, 2 and 1 (each within the scatter of the next).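

The exchange of one aryl group for another on this nitrogen gives a 1.2-fold lower number from compound 2 to compound 3 (0.08 log units; within the scatter) in this assay and so stays within the scatter, while replacing octyl with 4-fluorophenyl gives a 1.5-fold lower number from compound 1 to compound 3 (0.17 log units; within the scatter) and also stays within it. On this nitrogen, octyl, 3-chlorophenyl and 4-fluorophenyl therefore cannot be told apart in this read-out. No available evidence bears on this result. On these data alone, whether a carboxylic acid or an amine on the phenyl ring, or a shorter chain in place of octyl, would move the number beyond the scatter remains open.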